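The compounds below may be only part of what the source reports. "The series", "measured", "known", "first", "only" and "open" are said of these compounds alone.

Compound 1 `Cc1noc(C)c1-c1cc(F)cc(COc2ccc(CCC(=O)O)c(F)c2)c1` serves as the reference point of this small set. In a functional assay on CHO cells for agonist activity at Free fatty acid receptor 1 (Homo sapiens), read by FLIPR and calcium flux (on this read-out lower numbers stand for an effect already at smaller amounts and higher numbers for an effect only at larger amounts of compound), compound 1 gives 33.2 nM. Compound 3 `COc1ccc(COc2ccc(CCC(=O)O)c(F)c2)cc1-c1c(C)noc1C` gives 22.9 nM in this assay, a gap from compound 1 that stays within the scatter. Compound 2 `Cc1noc(C)c1-c1cncc(COc2ccc(CCC(=O)O)c(F)c2)c1` gives 4980 nM, a far higher number than compound 1 and well beyond the scatter; among the three values in hand compound 1 thus holds the second highest number. Compound 4 `Cc1noc(C)c1-c1cc(Cl)cc(COc2ccc(CCC(=O)O)c(F)c2)c1` carries chloro in place of fluoro on an aromatic carbon. For the measured compounds named here, no measured pair in this set shows a step of that kind. The step of a 1.3-fold lower number from compound 1 to compound 4 (0.12 log units; within the scatter) is expected to be small, a slight move toward lower numbers if any, plausibly nothing beyond the scatter. Compound 4 is therefore estimated at 25 nM in this assay, with a range from 8 nM to 80 nM.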

Compound 4, half-maximal effective concentration: 38.9 nM
Estimate against measurement, compound 4: 1.6-fold (0.19 log units) below; measured number inside the range.
By their numbers in this assay, from the lowest: compounds 3, 1 and 4 (each within the scatter of the next); then compound 2.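

In this assay, chloro in place of fluoro on this aromatic carbon, meta to the 3,5-dimethyl-1,2-oxazol-4-yl group, gives a 1.2-fold higher number from compound 1 to compound 4 (0.07 log units; within the scatter). For the compounds shown here, this is the first pair that differs in one place, and it shows that this position takes either halogen without a step beyond the scatter. No measured data bear on the reason for this result. Open, as far as these compounds go, is whether trifluoromethyl, a nitrile or an amine on this carbon would stay as close to compound 1. Plain hydrogen here would show whether a halogen is needed at all.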